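This account rests on a few compounds, and the source may have more. Where it says the series, first, only, none or still open, it means among the compounds named here.

Compound 1 `O=C(CN1CCN(c2nnc(Cc3ccncc3)c3ccccc23)CC1)Nc1ccc(F)c(Cl)c1`: 4 nM
Compound 2 `O=C(CN1CCN(c2nnc(Cc3ccncc3)c3ccccc23)CC1)Nc1cccc(Br)c1`: 1.7 nM

Both values come from a functional assay on MDA-MB-231 cells (Homo sapiens) for cytotoxicity, read by MTT assay, with a stated time of 72 h; on this read-out higher numbers stand for weaker inhibition and lower numbers for stronger inhibition. Within the data shown here, compound 2 holds the lowest of the two numbers; its nearest neighbour is compound 1, and the one step that joins them, a 2.4-fold lower number from compound 1 to compound 2 (0.37 log units; beyond the scatter), is the only measured step here. Compound 3 `O=C(CN1CCN(c2nnc(Cc3ccncc3)c3ccccc23)CC1)Nc1cc(C(F)(F)F)ccc1Cl` carries the change (2-chloro-5-(trifluoromethyl)phenyl in place of 3-bromophenyl on an amide-type nitrogen). The measured step bears on it only loosely: it shows that swapping one substituted phenyl for another on this amide nitrogen moves the number modestly, and a return to a two-substituent ring points toward a modest rise. Compound 3 is therefore expected to give 4 nM, within 1.5 nM to 12 nM, so that the expected step is a 2.4-fold higher number from compound 2 to compound 3 (0.37 log units; beyond the scatter).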

Compound 3, half-maximal inhibitory concentration: 3.7 nM
Compound 3: the middle estimate sits 1.1-fold (0.03 log units) above what was measured, and the stated range covers the measured number.
By their numbers in this assay, from the lowest: compound 2; then compounds 3 and 1 (each within the scatter of the next).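

In this assay, 3-bromophenyl on the amide-type nitrogen stays ahead of a second, differently substituted ring, with a 2.2-fold higher number from compound 2 to compound 3 (0.34 log units; beyond the scatter). The 3-chloro-4-fluorophenyl and 2-chloro-5-(trifluoromethyl)phenyl groups cannot be told apart at this position, with a 1.1-fold lower number from compound 1 to compound 3 (0.03 log units; within the scatter). No supporting data offer an explanation for either step.

The compounds shown leave open how an unsubstituted phenyl would read here. They also leave open whether a phenyl ring bearing an amine or a carboxylic acid would hold numbers in this range.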